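Replacing the 1-carboxy-2-methylbutyl group of compound 2

The compounds below may be only part of what the source reports. "The series", "measured", "known", "first", "only" and "open" are said of these compounds alone.

Compound 1 `CCn1c(C(=O)N(CCC#N)CCC#N)ccc1C(CC)(CC)c1ccc(OCCC(O)(CC)CC)c(C)c1`: > 50000 nM (a limit)
Compound 2 `CCC(C)C(NC(=O)c1ccc(C(CC)(CC)c2ccc(OCCC(O)(CC)CC)c(C)c2)n1CC)C(=O)O`: 13800 nM

Among the compounds with values here, in a functional assay on PC-3 cells (Homo sapiens) for antiproliferative activity, read by MTT assay, with a stated time of 48 h (a lower number here means a stronger inhibitor, a higher number a weaker inhibitor), compound 2 gives 13800 nM, the only true number so far.

The result for compound 1 is a limit, > 50000 nM.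

Compound 3 `CCn1c(C(=O)NC(CO)CCO)ccc1C(CC)(CC)c1ccc(OCCC(O)(CC)CC)c(C)c1` departs from compound 2 in one place: 3-hydroxy-1-(hydroxymethyl)propyl in place of 1-carboxy-2-methylbutyl on an amide-type nitrogen. There, 3-hydroxy-1-(hydroxymethyl)propyl stands in place of 1-carboxy-2-methylbutyl on an amide-type nitrogen.

Within the data shown here, one measured step bears on this, an at least 3.6-fold lower number from compound 1 to compound 2 (0.55 log units; beyond the scatter). As far as these compounds go, it starts from a limit (the limit of > 50000 nM in this assay, at which 1 of the 2 values shown sits), so its full size is unknown. It also arrives at the group that compound 3 gives up. A modest step towards a weaker inhibitor is therefore expected in this assay, though this rests on a single comparison.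

The expected step is a 1.6-fold higher number from compound 2 to compound 3 (0.20 log units; within the scatter).

For compound 3 the estimated value is 22000 nM, with an expected range from 7000 nM to 60000 nM.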

Compound 3, half-maximal inhibitory concentration: 8760 nM
Compound 3: the middle estimate sits 2.5-fold (0.40 log units) above what was measured; low and high end bracket the measured number.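

On the amide-type nitrogen, 3-hydroxy-1-(hydroxymethyl)propyl takes the place of 1-carboxy-2-methylbutyl with no change that can be told apart from the scatter in this assay: the step is a 1.6-fold lower number from compound 2 to compound 3 (0.20 log units; within the scatter). Compound 3 carries no carboxylic acid, so in this pair the acid is not needed for a value of this order. The other new step, an at least 5.7-fold lower number from compound 1 to compound 3 (0.75 log units; beyond the scatter), lies beyond the scatter, but it starts from a limit and its full size cannot be read: the limit of > 50000 nM in this assay, at which 1 of the 3 values shown sits.

The two groups differ in chain as well as in their oxygen functions, so this pair does not show which of these differences matters, if either does. It also leaves open how an amine, a methyl ester or a longer chain carrying a single hydroxyl would fare on this nitrogen.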